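Series notes: aryl exchange on the ring amine nitrogen

The source may hold more compounds than are shown below. What is called first, only, known or untested is meant among the compounds shown, and "the series" means these compounds.

Measured so far in a functional assay on CHO cells with adenosine receptor A1 (Homo sapiens) as the target, read by cAMP accumulation and immunoassay, with a stated time of 6 min, tested at 10 uM; a lower number here means a stronger effect, a higher number a weaker effect of the compound at the concentration tested:
compound 1 `Nc1scc(CN2CCN(c3ccc(Cl)cc3Cl)CC2)c1C(=O)c1ccc(Cl)cc1` gives -74%
compound 2 `Nc1scc(CN2CCN(c3ccc(Cl)c(C(F)(F)F)c3)CC2)c1C(=O)c1ccc(Cl)cc1` gives -60%
compound 3 `Nc1scc(CN2CCN(c3c(F)cccc3F)CC2)c1C(=O)c1cccc(C(F)(F)F)c1` gives 4%

Compound 2 stands second highest of the three numbers; compound 1 lies lower, compound 3 far higher. Among the measured compounds shown here, the only single-place step, a number 14 percentage points higher from compound 1 to compound 2 (beyond the scatter), shows that exchanging the aryl group on the amine nitrogen in a ring shifts the read-out beyond the scatter. Compound 4 `Nc1scc(CN2CCN(c3c(F)cc(F)cc3F)CC2)c1C(=O)c1ccc(Cl)cc1` is another such exchange: 2,4,6-trifluorophenyl in place of 4-chloro-3-(trifluoromethyl)phenyl on an amine nitrogen in a ring. For the measured compounds named here, no measured step bears directly on it. Compound 3 also carries fluorine on the aryl group at that nitrogen and differs in a second place as well; its value sits far above that of compound 2. A rise in this assay is therefore expected, a number 35 percentage points higher from compound 2 to compound 4 (beyond the scatter). Compound 4 is estimated at -25%, between -60% and 5%.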

Compound 4, a percentage reported as activity, at one concentration (the size of the read-out at that concentration, not a potency): -78%
The estimate for compound 4 lay 53 percentage points above the measured number; measured number outside the range, below it.
By their numbers in this assay, from the lowest: compounds 4 and 1 (each within the scatter of the next); then compound 2; then compound 3.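

Exchanging the aryl group on the amine nitrogen in a ring moves the read-out in this assay in both directions: a number 18 percentage points lower from compound 2 to compound 4 (beyond the scatter), whereas a number 4 percentage points lower from compound 1 to compound 4 (within the scatter), so compound 1 and compound 4 cannot be told apart. Fluorine alone on this aryl group therefore does not go with a higher number. No measurement at hand accounts for these differences.

As far as these compounds go, whether an aryl group without halogen, such as methoxyphenyl, would hold the read-out at this level remains open. Also open, from the compounds shown here alone, is how a carboxylic acid on this aryl group would read.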